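Methyl on the aromatic ring of a coumarin-like inhibitor

The source may hold more compounds than are shown below. What is called first, only, known or untested is meant among the compounds shown, and "the series" means these compounds.

Measured so far:
Compound 1 `O=C(CCN1CCCC1)c1cc2ccc(O)cc2oc1=O` — in an assay on cells for inhibition of Amine oxidase [flavin-containing] A (Homo sapiens), read by fluorescence, spectrophotometry and Amplex Red, with stated times of 60 min and 30 min (on this read-out higher numbers stand for weaker inhibition and lower numbers for stronger inhibition), compound 1 gives > 200000 nM, which is a limit of the assay and not a number.
Compound 2 `O=C(CCN1CCCCC1)c1cc2ccc(O)cc2oc1=O` — in this assay compound 2 gives > 200000 nM, again a limit of the assay.
Compound 3 `COc1ccc2cc(C(=O)CCN3CCCC3)c(=O)oc2c1` — in this assay compound 3 gives 53100 nM.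

Compound 1 therefore stands only at the limit of > 200000 nM in this assay, at which 2 of the 3 values shown sit, with no exact number of its own. Compound 4 `Cc1cc(O)cc2oc(=O)c(C(=O)CCN3CCCC3)cc12` is not yet measured; it differs from compound 1 by methyl in place of hydrogen on an aromatic carbon. Among the measured compounds shown here, no measured step makes the same change. The two steps that start from compound 1 are a step that the two limits leave unreadable from compound 1 to compound 2, which the two limits leave unreadable, and an at least 3.7-fold lower number from compound 1 to compound 3 (0.57 log units; beyond the scatter), which also adds a methyl, though on an oxygen rather than on a ring carbon. The expectation for compound 4 is a small step, a number no higher from compound 1 to compound 4 (the limit leaves the size open), with a fair chance that the assay again reports only a limit. Compound 4 is estimated at 200000 nM, within a range from 50000 nM to 800000 nM.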

Compound 4, half-maximal inhibitory concentration: 173000 nM
Estimate against measurement, compound 4: 1.2-fold (0.06 log units) above, and the stated range covers the measured number.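

In this assay, a methyl on this aromatic carbon gives an at least 1.1-fold lower number from compound 1 to compound 4 (0.06 log units; that floor lies within the scatter), so this change shows no difference that can be told from the scatter. Even so, compound 4 gives an exact number, 173000 nM, which provides a measured value for a compound with a methyl at this ring position. A methyl on the oxygen reads differently, with an at least 3.7-fold lower number from compound 1 to compound 3 (0.57 log units; beyond the scatter), so the two placements of the same small group cannot be treated as equivalent.

The true size of the ring-methyl step stays open because compound 1 has only a limit of the assay and no exact number: the limit of > 200000 nM in this assay, at which 2 of the 4 values shown sit.

Also open, as far as these compounds go, is whether an ethyl group, a chlorine atom or an amine on the same aromatic carbon would read differently, and whether the ring methyl would behave alike with the piperidin-1-yl chain of compound 2.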